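Aryl amide variation on the chromone ether series

The source may hold more compounds than are shown below. What is called first, only, known or untested is meant among the compounds shown, and "the series" means these compounds.

Within the data shown here, compound 2 `Nc1cccc(C(=O)Nc2cccc(NC(=O)COc3ccc4c(=O)ccoc4c3)c2)c1` stands at the higher end of the two numbers so far: in an assay on isolated protein for inhibition of Rho-associated protein kinase 1 (Homo sapiens), read by scintillation counting, radiometric assay and 33P incorporation, with a stated time of 40 min, in the presence of a further agent that is not named here (a higher number here means a weaker inhibitor, a lower number a stronger inhibitor), compound 2 gives 670 nM, whereas compound 1 `CC(C)(C)c1ccc(C(=O)Nc2cccc(NC(=O)COc3ccc4c(=O)ccoc4c3)c2)cc1` gives 165 nM. Among the measured compounds shown here, the one step between them, a 4.1-fold higher number from compound 1 to compound 2 (0.61 log units; beyond the scatter), is the only measured change on the aryl group of the outer amide, and it describes exactly the place that is altered again here.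

Compound 3 `O=C(COc1ccc2c(=O)ccoc2c1)Nc1cccc(NC(=O)c2ccc(C(=O)O)cc2)c1` differs from compound 2 in a single place: 4-carboxyphenyl in place of 3-aminophenyl on a carbonyl carbon. The earlier step shows that the group on this carbonyl carbon moves the number by a modest amount, but it compared a 4-(tert-butyl)phenyl with a 3-aminophenyl, not an aminophenyl with a carboxyphenyl, so it sets the scale of what one swap here can do rather than its direction. For the measured compounds named here, with only that one step to go on, the expectation for compound 3 in this assay is a step of a 1.5-fold higher number from compound 2 to compound 3 (0.17 log units; within the scatter), close to the scatter and, if anything, towards a weaker inhibitor. Compound 3 is therefore estimated at 1000 nM, within a range from 300 nM to 3500 nM.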

Compound 3, half-maximal inhibitory concentration: 6890 nM
Compound 3: the middle estimate sits 6.9-fold (0.84 log units) below what was measured; the whole stated range lies below it.
By their numbers in this assay, from the lowest: compound 1; then compound 2; then compound 3.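

In this assay, the group on this carbonyl carbon can move the number much further than the first step suggested, with a 10-fold higher number from compound 2 to compound 3 (1.01 log units; beyond the scatter). The cleanest reading comes from the two groups substituted at the same ring position, 4-(tert-butyl)phenyl and 4-carboxyphenyl, where exchanging tert-butyl for carboxy gives a 42-fold higher number from compound 1 to compound 3 (1.62 log units; beyond the scatter), the largest step in the set and one that makes the outer aryl group a strong determinant of the number in this series. Nothing available accounts for the size of these steps.

The step from 3-aminophenyl to 4-carboxyphenyl changes both the substituent and its place on the ring, so the compounds shown do not separate those two contributions; 3-carboxyphenyl and 4-aminophenyl would divide them. On these data alone, it also remains open whether the high number belongs to the carboxylic acid itself or would persist with a methyl ester, a primary amide or a hydroxymethyl group in the same place, or with the acid carried on a longer chain.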